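This account rests on a few compounds, and the source may have more. Where it says the series, first, only, none or still open, it means among the compounds named here.

Values so far in a functional assay on A549 cells (Homo sapiens) for antiproliferative activity, read by sulforhodamine B assay, with a stated time of 48 h; a lower number here means a stronger inhibitor of growth, a higher number a weaker inhibitor of growth:
- compound 1 `Cc1ccc(C(=O)c2ccc3nc(/C=C/C(=O)NO)ccc3c2)cc1`: 2580 nM
- compound 2 `COc1ccc(C(=O)c2ccc3nc(/C=C/C(=O)NO)ccc3c2)cc1`: 1890 nM
- compound 3 `COc1ccc(C(=O)c2ccc3nc(/C=C/C(=O)NO)ccc3c2)cc1OC`: 3310 nM

These three values all lie within the usual scatter of one another, so compound 3 at 3310 nM cannot be told apart from the other two. The next compound to consider is compound 4 `COc1cc(C(=O)c2ccc3nc(/C=C/C(=O)NO)ccc3c2)cc(OC)c1OC`, which differs from compound 3 by one change: methoxy in place of hydrogen on an aromatic carbon.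

For the measured compounds named here, the closest precedent is the same kind of change, a 1.8-fold higher number from compound 2 to compound 3 (0.24 log units; within the scatter), and that step lies within the scatter. The other available step, a 1.4-fold lower number from compound 1 to compound 2 (0.14 log units; within the scatter), swaps methoxy in for methyl and also lies within the scatter. Going by the values given here, neither step points to a clear trend, and no compound measured so far carries this third methoxy group. In this assay, then, no step beyond the scatter is expected, and no direction can be favoured with any confidence. The expected change is small, a 1.1-fold lower number from compound 3 to compound 4 (0.04 log units; within the scatter) in this estimate. Compound 4 is estimated at 3000 nM as the expected value, with an expected range from 1200 nM up to 7000 nM as its limits.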

Compound 4, concentration for 50% growth inhibition: 3350 nM
The estimate for compound 4 lay 1.1-fold (0.05 log units) below the measured number, within the range that was stated.
By their numbers in this assay, from the lowest: compounds 2, 1, 3 and 4 (each within the scatter of the next).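

In this assay, for the compounds shown here, the third methoxy group gives a 1.0-fold higher number from compound 3 to compound 4 (0.01 log units; within the scatter), so a methoxy group on this aromatic carbon, ortho to one methoxy group and meta to another, brings no step that can be told from the scatter. Together with a 1.8-fold higher number from compound 2 to compound 3 (0.24 log units; within the scatter), this means that methoxy in place of hydrogen has now been seen at two different carbons of this ring, and neither step lies beyond the scatter. No measurement is at hand that would explain this flat result.

All the compounds shown carry only methyl or methoxy groups on this ring, so it remains open whether an amine or a carboxylic acid on this same carbon would give a step beyond the scatter. From the compounds shown here alone, it also remains open whether a longer chain, such as butoxy, in place of one of the methoxy groups would stay within the scatter or would show that this part of the molecule can affect growth inhibition in these cells.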